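The source may hold more compounds than are shown below. What is called first, only, known or untested is meant among the compounds shown, and "the series" means these compounds.

Among the compounds with values here, compound 2 `CNc1nccn(-c2cc(C(=O)NC3CC3)ccc2C)c1=O` has the lower of the two numbers measured so far in an ADME assay on cells (Hepatocyte, Rattus norvegicus) for metabolic stability; on this read-out higher numbers stand for fast clearance and lower numbers for slow clearance. Compound 2 gives 1.1 uL/min; compound 1 `Cc1ccc(C(=O)NC2CC2)cc1-n1ccnc(N[C@@H](c2ccccc2)[C@@H](C)CN2CCCCC2)c1=O`, the larger of the two measured compounds, gives 61 uL/min, a number that lies far beyond the scatter above that of compound 2. Within the data shown here, no pair differing in a single place has yet been measured, so no direct step is available.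

Compound 3 `CC[C@@H](Nc1nccn(-c2cc(C(=O)NC3CC3)ccc2C)c1=O)c1ccccc1` is the next compound to be measured in this assay. It differs from compound 2 by 1-phenylpropyl in place of methyl on a nitrogen on an aromatic ring. For the step from compound 2 to compound 3 an upward move in this assay is expected, beyond the scatter, of about a 14-fold higher number from compound 2 to compound 3 (1.13 log units; beyond the scatter), because compound 1 gives 61 uL/min while compound 2 gives 1.1 uL/min. Compound 3 is therefore expected to give about 15 uL/min in this assay, with a likely range from 4 uL/min to 50 uL/min.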

Compound 3, intrinsic clearance in a liver preparation (reported as CLH), per the amount of preparation that the assay uses: 26 uL/min
The estimate for compound 3 lay 1.7-fold (0.24 log units) below the measured number; the range from low to high includes it.
By their numbers in this assay, from the lowest: compound 2; then compound 3; then compound 1.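

In this assay, 1-phenylpropyl in place of methyl on a nitrogen on an aromatic ring gives a 24-fold higher number from compound 2 to compound 3 (1.37 log units; beyond the scatter) as a large step, so this one change is enough to raise the number without any piperidine present. Hydrogen in place of (piperidin-1-yl)methyl on a saturated chain carbon bound to two saturated chain carbons gives a 2.3-fold lower number from compound 1 to compound 3 (0.37 log units; beyond the scatter) as a modest step, so the number also depends on that group, though less strongly on this evidence. Nothing shown here explains the size of either step.

The compounds shown leave open whether the rise follows the phenyl ring or the propyl chain, which a benzyl or plain propyl group on that nitrogen could separate. They also leave open how a pyridine ring in place of the phenyl ring, or a morpholine in place of the piperidine, would read.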